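A few compounds are considered here, and "the series" means these few. Any claim that something is new, unique, unknown or untested is made for them only; others in the source may bear on it.

Measured compounds:
Compound 1 `C/C(CN(C[C@H]1Cc2ccccc2CN1)[C@H]1CCCc2cccnc21)=C(/F)CN`: in an ADME assay on microsomes from liver (Mus musculus) for metabolic stability (on this read-out lower numbers stand for a less stable compound and higher numbers for a more stable compound), compound 1 gives 15%.
Compound 2 `C/C(CN)=C(\F)CN(C[C@H]1Cc2ccccc2CN1)[C@H]1CCCc2cccnc21`: compound 2 gives 2%.
Compound 3 `C/C(CN(C[C@H]1Cc2ccccc2CN1)[C@H]1CCCc2cccnc21)=C(\F)CN`: compound 3 gives 1%.

Compound 1 stands highest of the three: a number 13 percentage points lower from compound 1 to compound 2 (beyond the scatter) and a number 14 percentage points lower from compound 1 to compound 3 (beyond the scatter). Compounds 2 and 3 sit within the scatter of each other, a number 1 percentage points lower from compound 2 to compound 3 (within the scatter). The step from compound 1 to compound 3 is notable given (the fact that compounds 1 and 3 differ only in the configuration as drawn). Compound 4 `N[C@H]1CC[C@@H](N(C[C@H]2Cc3ccccc3CN2)[C@H]2CCCc3cccnc32)CC1` derives from compound 1 by 4-aminocyclohexyl in place of 4-amino-3-fluoro-2-methylbut-2-en-1-yl on an amine nitrogen. Both measured steps reshaped the same group that is now replaced outright, and both were modest and downward; neither introduced a saturated ring, so they bound the new step only loosely. A modest step in either direction is plausible; the expected step is a number 5 percentage points higher from compound 1 to compound 4 (within the scatter). For compound 4 the estimate is 20%, expected to lie between 4% and 50%.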

Compound 4, percent of the compound remaining: 56%
Beside the measured number, compound 4's estimate is 36 percentage points below it, and the stated range ends below it.
By their numbers in this assay, from the lowest: compounds 3 and 2 (each within the scatter of the next); then compound 1; then compound 4.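

In this assay the step of a number 41 percentage points higher from compound 1 to compound 4 (beyond the scatter) is large, as are a number 54 percentage points higher from compound 2 to compound 4 (beyond the scatter) and a number 55 percentage points higher from compound 3 to compound 4 (beyond the scatter) in the same direction, all with 4-aminocyclohexyl entering on the amine nitrogen. This position therefore responds far more to replacing the open chain outright than to the reshaping seen among compound 1, compound 2 and compound 3. Nothing given here bears on why the number rises.

On these data alone, the change adds a ring and removes the fluorine and the double bond together, so the share of each stays open. A saturated 4-aminobutyl chain or a piperidin-4-yl group on the same nitrogen would help separate them.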